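A few compounds are considered here, and "the series" means these few. Any claim that something is new, unique, unknown or untested is made for them only; others in the source may bear on it.

Measured compounds:
compound 1 `COc1ccc(N(CC(=O)NCCCSc2ccccc2)C(=O)/C=C/c2ccccc2)cc1`: 4
compound 2 `COc1ccc(N(CC(=O)NCCCSc2ccccc2)C(=O)c2ccccc2)cc1`: 3.1

Of these two numbers in a physicochemical assay for lipophilicity, read by HPLC, measured as octanol-water partition (a higher number here means a more lipophilic compound, a lower number a more polar compound), compound 1 stands highest; the step of a number 0.90 log units lower from compound 1 to compound 2 (beyond the scatter) lies beyond the scatter. Compound 3 `COc1ccc(N(CC(=O)NCCC[Te]c2ccccc2)C(=O)/C=C/c2ccccc2)cc1` has not yet been measured. It differs from compound 1 in one place: a group of 7 heavy atoms (6 carbon, 1 tellurium; one six-membered aromatic ring of carbon only) in place of a group of 7 heavy atoms (6 carbon, 1 sulfur; one six-membered aromatic ring of carbon only), on a saturated chain carbon, three bonds along the chain from an amide-type nitrogen. For the measured compounds named here, the only measured step, a number 0.90 log units lower from compound 1 to compound 2 (beyond the scatter), changes a different part of the molecule, so no measured step bears directly on this exchange. With nothing to guide the size, the expected step is a number 0.20 log units higher from compound 1 to compound 3 (within the scatter), not beyond the scatter. The estimate for compound 3 is 4.2, ranging from 3.6 to 4.9.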

Compound 3, partition coefficient: 1.31
Compound 3: the middle estimate sits 2.89 log units above what was measured, outside the stated range (below it).
By their numbers in this assay, from the lowest: compound 3; then compound 2; then compound 1.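

In this assay, exchanging phenylsulfanyl for its tellurium counterpart gives a number 2.69 log units lower from compound 1 to compound 3 (beyond the scatter) on a saturated chain carbon, three bonds along the chain from an amide-type nitrogen. The aromatic ring and the count of heavy atoms stay the same, so this position responds strongly to a change of one atom, something the earlier step at the carbonyl could not show. Nothing measured here explains the size of this step. As far as these compounds go, whether a selenium atom in this place would give a number nearer compound 1 or compound 3 stays open, as does the effect of a longer chain carrying tellurium.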